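Amide variation on the shared core of compound 2

The source may hold more compounds than are shown below. What is called first, only, known or untested is meant among the compounds shown, and "the series" means these compounds.

Among the measured compounds shown here, compound 2 `COc1ncc(-c2ccc3nc(NC(C)=O)nn3c2)cc1NS(=O)(=O)c1ccc(F)cc1` gives 1820 nM in a functional assay on U-87MG ATCC cells (Homo sapiens) for antiproliferative activity, read by MTT assay, with a stated time of 48 h (a lower number here means a stronger inhibitor, a higher number a weaker inhibitor), the lowest of the three numbers measured so far. Compound 1 `CC(=O)Nc1nc2ccc(-c3cnc(Cl)c(NS(=O)(=O)c4ccc(F)cc4)c3)cn2n1` gives 6950 nM in this assay, and compound 3 `COc1ncc(-c2ccc3nc(NC(C)=O)nn3c2)cc1NS(=O)(=O)c1ccc(C2CC2)cc1` gives 3730 nM in this assay. The two measured steps, a 3.8-fold lower number from compound 1 to compound 2 (0.58 log units; beyond the scatter) and a 2.0-fold higher number from compound 2 to compound 3 (0.31 log units; beyond the scatter), both alter substituents on aromatic rings of the shared core. Compound 4 `CCOC(=O)CNc1nc2ccc(-c3cnc(OC)c(NS(=O)(=O)c4ccc(F)cc4)c3)cn2n1` differs from compound 2 in (ethoxycarbonyl)methyl in place of acetyl on a nitrogen on an aromatic ring. Neither measured step touches this nitrogen, so nothing measured speaks directly to the size or direction of this change. For compound 4 the expected step is therefore a 1.4-fold higher number from compound 2 to compound 4 (0.14 log units; within the scatter), none beyond the scatter. Compound 4 is estimated at 2500 nM in this assay, with a range of 900 nM to 7000 nM.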

Compound 4, half-maximal inhibitory concentration: 7940 nM
For compound 4 the middle estimate is 3.2-fold (0.50 log units) below the measured one; the whole stated range lies below it.
By their numbers in this assay, from the lowest: compound 2; then compounds 3, 1 and 4 (each within the scatter of the next, the first and the last beyond it).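

In this assay, (ethoxycarbonyl)methyl in place of acetyl gives a 4.4-fold higher number from compound 2 to compound 4 (0.64 log units; beyond the scatter), so activity in this series responds to the group on this nitrogen. Among the compounds shown here, the earlier steps covered only substituents on aromatic rings, and this is the first reading at this position, where the acetamido group of compound 2 gives the lower number. Nothing available accounts for this step.

Still open, from the compounds shown here alone, is whether the ester or the loss of the acetyl group carries the step. A carboxylic acid in place of the ethyl ester, or a longer acyl chain such as propionyl, would help separate the two.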